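Swapping the Aryl Tail for a Benzothiophene

This account rests on a few compounds, and the source may have more. Where it says the series, first, only, none or still open, it means among the compounds named here.

Two compounds share one core. Compound 2 `CC(C)C[C@H](N)c1cc(C(F)(F)F)ccc1N1CCN(C(=O)CCc2c(Cl)cccc2Cl)CC1` gives 2600 nM in an assay on HEK293 cells for displacement of a labelled ligand from Melanocortin receptor 4 (Homo sapiens) (on this read-out higher numbers stand for weaker inhibition and lower numbers for stronger inhibition), and compound 1 `CC(C)C[C@H](N)c1cc(C(F)(F)F)ccc1N1CCN(C(=O)CCc2cccc(C(F)(F)F)c2)CC1` gives 2200 nM in this assay. For the measured compounds named here, the only measured step, a 1.2-fold higher number from compound 1 to compound 2 (0.07 log units; within the scatter), stays within the scatter, so neither number stands apart. Compound 3 `CC(C)C[C@H](N)c1cc(C(F)(F)F)ccc1N1CCN(C(=O)CCc2csc3ccccc23)CC1` differs from compound 2 by 1-benzothiophen-3-yl in place of 2,6-dichlorophenyl on a saturated chain carbon, two bonds along the chain from a carbonyl carbon. Going by the values given here, since the one comparable change, a 1.2-fold higher number from compound 1 to compound 2 (0.07 log units; within the scatter), moved the number only within the scatter, the step of a 1.1-fold lower number from compound 2 to compound 3 (0.03 log units; within the scatter) is expected to stay within the scatter as well. Compound 3 is therefore estimated at 2400 nM in this assay, with a range from 800 nM to 7000 nM.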

Compound 3, inhibition constant: 2300 nM
For compound 3 the middle estimate is 1.0-fold (0.02 log units) above the measured one; low and high end bracket the measured number.
By their numbers in this assay, from the lowest: compounds 1, 3 and 2 (each within the scatter of the next).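

Replacing a single aromatic ring with 1-benzothiophen-3-yl, which has a five-membered aromatic ring with sulfur as well as a six-membered carbon ring, gives a 1.1-fold lower number from compound 2 to compound 3 (0.05 log units; within the scatter) in this assay and a 1.0-fold higher number from compound 1 to compound 3 (0.02 log units; within the scatter) as the comparison with the 3-(trifluoromethyl)phenyl tail. So at this position, three quite different aromatic groups now give numbers within the scatter of one another. Nothing available explains this flatness. Still open, from the compounds shown here alone, is whether a tail ending in an amine or a carboxylic acid, or a longer chain to the aromatic group, would shift the number beyond the scatter.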